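Oxolan-2-yl for oxan-2-yl on the shared core

The source may hold more compounds than are shown below. What is called first, only, known or untested is meant among the compounds shown, and "the series" means these compounds.

In an ADME assay on BJ cells (Homo sapiens) for cytotoxicity, read by MTT assay, with a stated time of 72 h (on this read-out lower numbers stand for stronger inhibition and higher numbers for weaker inhibition), compound 1 (`COc1ccc(CNc2ncnc3c2ncn3C2CCCCO2)cc1`) gives > 100000 nM as a limit of the assay and not as a number. Compound 2 (`Oc1cc(O)cc(CNc2ncnc3c2ncn3C2CCCCO2)c1`) gives > 100000 nM as a limit too. Going by the values given here, compound 1 thus has no readable position, and the series so far shows only the limit of > 100000 nM in this assay, at which 2 of the 2 values shown sit, and no number.

Compound 3 (`COc1ccc(CNc2ncnc3c2ncn3C2CCCO2)cc1`) carries oxolan-2-yl in place of oxan-2-yl on an aromatic nitrogen and is otherwise the same as compound 1.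

Among the compounds with values here, the one measured step is a step that the two limits leave unreadable from compound 1 to compound 2 and it gives no size to carry over. Within the data shown here, that step changes a different place, so no measured step bears directly on this exchange. The expectation therefore rests on compound 1 with its limit of > 100000 nM and on nothing finer. No step beyond the scatter is expected in this assay, and a report as a limit is the likeliest outcome. The expected step is a number no higher from compound 1 to compound 3 (the limit leaves the size open) and its size is only an estimate. Compound 3 is estimated at 100000 nM with an expected range from 40000 nM to 250000 nM in this reading.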

Compound 3, half-maximal inhibitory concentration: > 100000 nM
Compound 3 gave a limit, no number (the forecaster's own chance of this, stated with the estimate: 85%); the middle value lies on the limit itself.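

In this assay compound 1 and compound 3 both stand only as limits of the assay, so no step can be read for oxolan-2-yl in place of oxan-2-yl. The compounds shown leave open how they rank against one another and whether any change on the shared core would give a number: the limit of > 100000 nM in this assay, at which 3 of the 3 values shown sit.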